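Changing the Aryl Group on the Amine Nitrogen

A few compounds are considered here, and "the series" means these few. Any claim that something is new, unique, unknown or untested is made for them only; others in the source may bear on it.

In a functional assay on HT-29 cells (Homo sapiens) for antiproliferative activity, read by MTT assay, with a stated time of 48 h (on this read-out lower numbers stand for stronger inhibition and higher numbers for weaker inhibition), compound 1 (`O=C(/C=C\Nc1ccc(F)cc1)c1cn(-c2ccccc2)nc1-c1ccccc1`) gives 6870 nM. Compound 2 (`O=C(/C=C\Nc1ccc(F)cc1)c1cn(-c2ccccc2)nc1-c1ccc(Cl)cc1`) reaches only a limit of the assay, > 50000 nM. Compound 3 (`COc1ccc(-c2nn(-c3ccccc3)cc2C(=O)/C=C\Nc2ccc(F)cc2)cc1`) gives 7650 nM, within the scatter of compound 1. Compound 4 (`COc1ccc(-c2nn(-c3ccccc3)cc2C(=O)/C=C\Nc2cc(OC)c(OC)c(OC)c2)cc1`) differs from compound 3 as follows: 3,4,5-trimethoxyphenyl in place of 4-fluorophenyl on an amine nitrogen. The measured steps, a 1.1-fold higher number from compound 1 to compound 3 (0.05 log units; within the scatter) and an at least 7.2-fold higher number from compound 1 to compound 2 (0.86 log units; beyond the scatter), both lie elsewhere in the molecule, so they bear on this change only indirectly, showing that one replacement can leave the number unmoved while another shifts it strongly. No step beyond the scatter is expected, though with wide uncertainty, and the step is estimated as a 1.5-fold lower number from compound 3 to compound 4 (0.18 log units; within the scatter). Compound 4 is expected near 5000 nM, with an estimated range of 1200 nM to 25000 nM.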

Compound 4, half-maximal inhibitory concentration: 14600 nM
Beside the measured number, compound 4's estimate is 2.9-fold (0.47 log units) below it; the measured number falls inside the stated range.
By their numbers in this assay, from the lowest: compounds 1, 3 and 4 (each within the scatter of the next, the first and the last beyond it). At a limit, above all of these: compound 2.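

In this assay, putting 3,4,5-trimethoxyphenyl in place of 4-fluorophenyl on the amine nitrogen gives a 1.9-fold higher number from compound 3 to compound 4 (0.28 log units; within the scatter). This is the first change shown at this position, and it indicates that this aryl group can be exchanged for one with three methoxy groups without a step beyond the scatter. Nothing in the data shown bears on why this step is so small.

From the compounds shown here alone, what a carboxylic acid or a longer alkyl chain in place of the aryl group on the amine nitrogen would do remains open. So does whether an unsubstituted phenyl there would give a similar number.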